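A few compounds are considered here, and "the series" means these few. Any claim that something is new, unique, unknown or untested is made for them only; others in the source may bear on it.

Of the compounds shown here, three sharing one core have been tested in a functional assay on PC-3 cells (Homo sapiens) for antiproliferative activity, read by sulforhodamine B assay, with a stated time of 72 h; a higher number here means a weaker inhibitor, a lower number a stronger inhibitor. Compound 1 `COc1ncc(-c2ccc3ncc(NCc4ccccc4)c(OC)c3c2)cc1NS(=O)(=O)c1ccc(F)cc1F`, with benzyl on the nitrogen, gives 4320 nM. Compound 2 `COc1ncc(-c2ccc3ncc(NCC4CCCCC4)c(OC)c3c2)cc1NS(=O)(=O)c1ccc(F)cc1F`, with cyclohexylmethyl there, gives 9000 nM, the highest number of the three, and its steps to both others lie beyond the scatter. Compound 3 `COc1ncc(-c2ccc3ncc(NC(=O)CN4CCN(C)CC4)c(OC)c3c2)cc1NS(=O)(=O)c1ccc(F)cc1F`, with ((4-methylpiperazin-1-yl)methyl)carbonyl on that nitrogen, gives 1730 nM.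

Compound 4 `COc1ncc(-c2ccc3ncc(NC(=O)CN4CCCC(O)C4)c(OC)c3c2)cc1NS(=O)(=O)c1ccc(F)cc1F` has not yet been measured. It departs from compound 2 as follows: ((3-hydroxypiperidin-1-yl)methyl)carbonyl in place of cyclohexylmethyl on a nitrogen on an aromatic ring. The nearest guide is a 5.2-fold lower number from compound 2 to compound 3 (0.72 log units; beyond the scatter), a modest step that replaces the same cyclohexylmethyl with another carbonyl-bearing group. The step of a 2.5-fold lower number from compound 1 to compound 3 (0.40 log units; beyond the scatter) points the same way, though it starts from benzyl. The step of a 2.1-fold higher number from compound 1 to compound 2 (0.32 log units; beyond the scatter) places compound 2 at the high end. Among the measured compounds shown here, no measured compound carries the ((3-hydroxypiperidin-1-yl)methyl)carbonyl group, so a modest step to a lower number in this assay is expected, similar in size to the nearest guide. The estimated change is a 3.9-fold lower number from compound 2 to compound 4 (0.59 log units; beyond the scatter). For compound 4 the expected value is 2300 nM, within an estimated range from 850 nM to 6000 nM.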

Compound 4, half-maximal inhibitory concentration: 1340 nM
Compound 4: middle estimate off by 1.7-fold (0.23 log units), on the high side; the measured number falls inside the stated range.
By their numbers in this assay, from the lowest: compounds 4 and 3 (each within the scatter of the next); then compound 1; then compound 2.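

In this assay, among the compounds shown here, the ((3-hydroxypiperidin-1-yl)methyl)carbonyl group on the nitrogen gives a 6.7-fold lower number from compound 2 to compound 4 (0.83 log units; beyond the scatter) and a 3.2-fold lower number from compound 1 to compound 4 (0.51 log units; beyond the scatter), so compound 3 is no longer the only carbonyl-bearing compound with a lower number than the two compounds carrying a ring on a plain carbon link. The ring at the end of that chain can also change with little visible effect: a 1.3-fold lower number from compound 3 to compound 4 (0.11 log units; within the scatter), and the 3-hydroxypiperidin-1-yl and 4-methylpiperazin-1-yl groups cannot be told apart here. Nothing available gives a reason for either result.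

From the compounds shown here alone, what a plain piperidin-1-yl, a 4-hydroxypiperidin-1-yl or a morpholin-4-yl would give on the same chain stays open. Going by these compounds, it is also open whether the carbonyl or the ring amine carries the change, as a simple acetyl on the nitrogen or a 2-(4-methylpiperazin-1-yl)ethyl group could separate the two.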